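The source may hold more compounds than are shown below. What is called first, only, known or untested is meant among the compounds shown, and "the series" means these compounds.

Working notes on the series built around the core of compound 1 `Cc1cccc(C(=O)N2CCCC(C(=O)Nc3ccc(Cl)cc3)C2)c1`. In an ADME assay on PC-3 cells (Homo sapiens) for cytotoxicity, read by WST assay, tested at 100 uM (on this read-out lower numbers stand for less inhibition and higher numbers for more inhibition at the one concentration tested (going by the name of the read-out)), compound 1 gives 0%, level at the digits shown with compound 2 `CC(C)(C)OC(=O)c1cccc(NC(=O)C2CCCN(C(=O)c3cc(C(F)(F)F)cc(C(F)(F)F)c3)C2)c1`, which gives 0%; compound 3 `O=C(Nc1cccc(OCCc2ccccn2)c1)C1CCCN(C(=O)c2cc(C(F)(F)F)cc(C(F)(F)F)c2)C1` gives 5%, within the scatter of both. Within the data shown here, the one measured step, a number 5 percentage points higher from compound 2 to compound 3 (within the scatter), concerns a change at another part of the molecule and stays within the scatter. Compound 4 `O=C(Nc1ccc(Cl)cc1)C1CCCN(C(=O)c2cccc(-c3cnco3)c2)C1` differs from compound 1 by 1,3-oxazol-5-yl in place of methyl on an aromatic carbon. Among the measured compounds shown here, no measured step bears directly on this change, and nothing in the three numbers moves beyond the scatter. For compound 4 the expected step is accordingly a number 2 percentage points higher from compound 1 to compound 4 (within the scatter), none beyond the scatter. Compound 4 is estimated at 2%, with a range from -5% to 15%.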

Compound 4, a percentage reported as inhibition, at one concentration (the size of the read-out at that concentration, not a potency): 0%
Compound 4: the middle estimate sits 2 percentage points above what was measured, and the stated range covers the measured number.
By their numbers in this assay, from the lowest: compounds 1, 2, 4 and 3 (each within the scatter of the next).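

In this assay, among these compounds, the exchange of methyl for 1,3-oxazol-5-yl on an aromatic carbon, meta to a large group, gives no change at the digits printed from compound 1 to compound 4 (within the scatter) as the only step read at this position. The position therefore takes a five-membered aromatic ring with 2 hetero atoms in place of a single carbon without a step beyond the scatter. No evidence available here bears on this result. As far as these compounds go, whether an amine, a carboxylic acid or a longer chain at this position would also stay within the scatter remains open.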